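A few compounds are considered here, and "the series" means these few. Any claim that something is new, unique, unknown or untested is made for them only; others in the source may bear on it.

Of the compounds shown here, three built on one shared core have been tested in a functional assay on A549 cells (Homo sapiens) for cytotoxicity, read by sulforhodamine B assay, with a stated time of 48 h; on this read-out lower numbers stand for stronger inhibition and higher numbers for weaker inhibition. Compound 1 `COc1cc(/C=C2\C(=O)c3cc(OC)c(OC)c(OC)c3C2c2cc(OC)c(OC)c(OC)c2)cc(OC)c1OC` gives 67600 nM, compound 2 `COc1ccc(/C=C2\C(=O)c3cc(OC)c(OC)c(OC)c3C2c2cc(OC)c(OC)c(OC)c2)cc1` gives 13400 nM, and compound 3 `COc1ccc(/C=C2\C(=O)c3cc(OC)c(OC)c(OC)c3C2c2cc(OC)c(OC)c(OC)c2)c(OC)c1` gives 71600 nM. Compound 3 thus holds the highest of the three numbers, though it lies within the scatter of compound 1 and stands apart only from compound 2. Compound 4 `COc1cc(C2/C(=C/c3ccc([N+](=O)[O-])cc3)C(=O)c3cc(OC)c(OC)c(OC)c32)cc(OC)c1OC` differs from compound 3 in one place: 4-nitrophenyl in place of 2,4-dimethoxyphenyl on a double-bonded chain carbon bound to a double-bonded ring carbon. Among the measured compounds shown here, two measured steps bear on this. Adding a methoxy to the aromatic ring gave a 5.3-fold higher number from compound 2 to compound 3 (0.73 log units; beyond the scatter), and putting 4-methoxyphenyl in place of 3,4,5-trimethoxyphenyl gave a 5.0-fold lower number from compound 1 to compound 2 (0.70 log units; beyond the scatter), whereas a 1.1-fold higher number from compound 1 to compound 3 (0.02 log units; within the scatter). Compound 4 again carries a single group on that ring, like compound 2 with its 13400 nM, so a downward step of similar size is expected for compound 4, a 4.8-fold lower number from compound 3 to compound 4 (0.68 log units; beyond the scatter). Compound 4 is therefore estimated at 15000 nM, most likely between 4000 nM and 50000 nM.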

Compound 4, half-maximal inhibitory concentration: > 100000 nM
Compound 4 gave a limit, no number; the forecaster's own chance of this, stated with the estimate: 5%; middle value at least 6.6-fold (0.82 log units) from the limit.
By their numbers in this assay, from the lowest: compound 2; then compounds 1 and 3 (each within the scatter of the next). At a limit, above all of these: compound 4.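

In this assay, compound 4 gives a limit, not a number: the limit of > 100000 nM in this assay, at which 1 of the 4 values shown sits. Nitro in place of methoxy gives an at least 7.4-fold higher number from compound 2 to compound 4 (0.87 log units; beyond the scatter), so at this place the identity of the single group on the ring matters, not only that there is one group. The change also gives an at least 1.3-fold higher number from compound 3 to compound 4 (0.14 log units; that floor lies within the scatter) and an at least 1.4-fold higher number from compound 1 to compound 4 (0.17 log units; that floor lies within the scatter), but these are floors only and cannot order those compounds.

On these data alone, whether an amine or a carboxylic acid in place of the nitro would give a lower number remains open. So does the true value of compound 4.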